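A few compounds are considered here, and "the series" means these few. Any claim that something is new, unique, unknown or untested is made for them only; others in the source may bear on it.

In a functional assay on BV-2 cells (Mus musculus) for inhibition, read by Griess assay, with a stated time of 24 h (a lower number here means a stronger inhibitor, a higher number a weaker inhibitor), compound 1 (`COc1ccc(Br)cc1-c1ccn(-c2ccccc2)n1`) gives > 200000 nM, which is a limit and not a number. Compound 2 (`COc1ccc(Br)cc1-c1ccn(Cc2ccccc2)n1`) gives > 200000 nM, likewise a limit. Compound 3 (`C=CCc1ccc(OC)c(-c2ccn(Cc3ccccc3)n2)c1`) differs from compound 2 by one change: allyl in place of bromo on an aromatic carbon. Among the measured compounds shown here, the only measured step, a step that the two limits leave unreadable from compound 1 to compound 2, concerns another place on the molecule and gives no size. For the measured compounds named here, the series so far offers only (the limit of > 200000 nM in this assay, at which 2 of the 2 values shown sit). Going by the values given here, no measured step bears on this change, so only a modest gain in this assay is expected, with the value staying high. The expected step is an at least 2.8-fold lower number from compound 2 to compound 3 (0.45 log units; beyond the scatter). For compound 3 the estimate is 70000 nM, with an expected range of 12000 nM to 300000 nM.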

Compound 3, half-maximal inhibitory concentration: 36000 nM
For compound 3 the middle estimate is 1.9-fold (0.29 log units) above the measured one; the measured number falls inside the stated range.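

In this assay, the place para to the methoxy group responds to substitution: allyl in place of bromo gives an at least 5.5-fold lower number from compound 2 to compound 3 (0.74 log units; beyond the scatter), with the size only a lower bound. Among the compounds shown here, this is the first readable step, as the step from compound 1 to compound 2 cannot be read. Compound 3 is the only compound shown that carries a number and not a limit: the limit of > 200000 nM in this assay, at which 2 of the 3 values shown sit.

Open, on these data alone, is whether a propyl chain or an amine at this place would give a similar drop. Also open, as far as these compounds go, is whether benzyl on the aromatic nitrogen still matters with allyl present.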